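A few compounds are considered here, and "the series" means these few. Any claim that something is new, unique, unknown or untested is made for them only; others in the source may bear on it.

In a functional assay on CCRF-CEM cells (Homo sapiens) (a lower number here means a stronger inhibitor, a higher number a weaker inhibitor), two compounds have been measured:

- compound 1 `Cc1ccc(-c2ncnc3c2ncn3C[C@@H]2C[C@H](CO)c3ccccc32)cc1`: 1.4 ug/mL
- compound 2 `Cn1ncc2c1[C@H](Cn1cnc3c(Cl)ncnc31)C[C@@H]2CO[Si](c1ccccc1)(c1ccccc1)C(C)(C)C`: 3.2 ug/mL

Compound 2 has the higher number of the two, and its gap to compound 1 lies beyond the scatter. Compound 3 `Cn1ncc2c1[C@H](Cn1ccc(=O)[nH]c1=O)C[C@@H]2CO[Si](c1ccccc1)(c1ccccc1)C(C)(C)C` has not yet been measured. Compared with compound 2, the change is a group of 8 heavy atoms (4 carbon, 2 nitrogen, 2 oxygen; one six-membered aromatic ring with 2 hetero atoms) in place of a group of 10 heavy atoms (5 carbon, 4 nitrogen, 1 chlorine; one five-membered aromatic ring with 2 hetero atoms, one six-membered aromatic ring with 2 hetero atoms), on a saturated chain carbon bound to a saturated ring carbon and the rest of the structure stays the same. Within the data shown here, no measured pair shows a change of this kind, so the expectation has only the two values above to rest on. A modest move towards a weaker inhibitor is expected, though a result within the scatter of compound 2 (3.2 ug/mL) would be no surprise. In this assay the expected step is a 1.9-fold higher number from compound 2 to compound 3 (0.27 log units; within the scatter) in that direction. For compound 3 the estimate is 6 ug/mL with 2.5 ug/mL and 18 ug/mL as the ends of the expected range.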

Compound 3, half-maximal inhibitory concentration: 3.2 ug/mL
For compound 3 the middle estimate is 1.9-fold (0.27 log units) above the measured one; the measured number falls inside the stated range.
By their numbers in this assay, from the lowest: compound 1; then compounds 2 and 3 (each within the scatter of the next).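

In this assay, putting the group of 8 heavy atoms with its single six-membered aromatic ring in place of the group of 10 heavy atoms with a five-membered and a six-membered aromatic ring gives no change at the digits printed from compound 2 to compound 3 (within the scatter). On a saturated chain carbon bound to a saturated ring carbon, the read-out therefore tolerates losing the chlorine and the five-membered aromatic ring while gaining a hydrogen-bond donor and two double bonds outside aromatic rings. Nothing measured here accounts for this result.

The compounds shown leave open how a phenyl group, an amine or a carboxylic acid would read at this place. They also leave open whether the same exchange would read alike on the core of compound 1.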